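Cytotoxicity notes: cyclohexylmethoxy to prenyloxy at the ether

A few compounds are considered here, and "the series" means these few. Any claim that something is new, unique, unknown or untested is made for them only; others in the source may bear on it.

Three members of the series share one core and differ only in the group on a saturated chain carbon bound to an oxygen on an unsaturated carbon. Compound 1 `CCC1(Cc2ccccc2)OS(=O)(=O)C=C1OCc1ccc(Cl)c(Cl)c1` carries 3,4-dichlorophenyl there. In an ADME assay on HEL cells (Homo sapiens) for cytotoxicity, with a stated time of 3 days (on this read-out lower numbers stand for higher toxicity in this test and higher numbers for lower toxicity in this test), compound 1 gives only a limit of the assay, >= 20000 nM. Compound 2 `CCC1(Cc2ccccc2)OS(=O)(=O)C=C1OCc1ccc([N+](=O)[O-])cc1` carries 4-nitrophenyl. In this assay compound 2 likewise gives a limit, >= 80000 nM. Compound 3 `CCC1(Cc2ccccc2)OS(=O)(=O)C=C1OCC1CCCCC1` carries cyclohexyl. In this assay compound 3 again gives a limit, >= 200000 nM. Since every value shown is a limit, compound 3 cannot be placed above or below the other two; the step that the two limits leave unreadable from compound 1 to compound 2, the step that the two limits leave unreadable from compound 1 to compound 3 and the step that the two limits leave unreadable from compound 2 to compound 3 are all unreadable, as the limit of >= 20000 nM in this assay, at which 1 of the 3 values shown sits, the limit of >= 80000 nM in this assay, at which 1 of the 3 values shown sits, and the limit of >= 200000 nM in this assay, at which 1 of the 3 values shown sits, show.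

Compound 4 `CCC1(Cc2ccccc2)OS(=O)(=O)C=C1OCC=C(C)C` is not yet measured in this assay. Against compound 3 the change is 2-methylprop-1-en-1-yl in place of cyclohexyl on a saturated chain carbon bound to an oxygen on an unsaturated carbon. The measured steps bear on it only in kind, all being exchanges at the same place, and none of them has a readable size. No direction beyond the scatter can therefore be expected for an at least 2.0-fold lower number from compound 3 to compound 4 (0.30 log units; that floor lies within the scatter), and compound 4 is expected to return a value near 100000 nM in this assay, estimated to lie between 20000 nM and 200000 nM, most probably again as a limit.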

Compound 4, minimum cytotoxic concentration: 400000 nM
Compound 4: middle estimate off by 4.0-fold (0.60 log units), on the low side; the measured number lies above the stated range.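

Compound 1, compound 2 and compound 3 each stand only as a limit of the assay in this assay, so none of their steps to compound 4 can be read. The compounds shown leave open whether exchanging 3,4-dichlorophenyl, 4-nitrophenyl or cyclohexyl for 2-methylprop-1-en-1-yl at this place changes the minimum cytotoxic concentration at all, and by how much.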